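Working notes on the amino ester series: towards compound 3

The source may hold more compounds than are shown below. What is called first, only, known or untested is meant among the compounds shown, and "the series" means these compounds.

Measured in a functional assay on ZR-75-1 cells (Homo sapiens) for inhibition, read by MTT assay, with a stated time of 24 h; a higher number here means a weaker inhibitor of growth, a lower number a stronger inhibitor of growth:
- compound 1 `CC(C)[C@H](N)C(=O)OC[C@H]1O[C@@H](n2cc(F)c(=O)[nH]c2=O)C[C@@H]1O`: 2500000 nM
- compound 2 `CC(C)[C@H](N)C(=O)OC[C@H]1O[C@@H](n2cc(F)c(=O)[nH]c2=O)C[C@@H]1OC(=O)[C@@H](N)C(C)C`: 2800000 nM

Going by the values given here, compound 2 carries the highest of the two numbers, but its only neighbour, compound 1, lies at a 1.1-fold higher number from compound 1 to compound 2 (0.05 log units; within the scatter), a step within the scatter, so the two values show no order between them.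

Compound 3 `CC(C)[C@H](N)C(=O)O[C@H]1C[C@H](n2cc(F)c(=O)[nH]c2=O)O[C@@H]1CO` differs from compound 2 by hydrogen in place of (1-amino-2-methylpropyl)carbonyl on an oxygen on a saturated carbon. The acyl group on the oxygen of the hydroxymethyl arm is lost, while the acyl group that entered between compound 1 and compound 2 remains in place.

Among the compounds with values here, one measured step bears on this change: a 1.1-fold higher number from compound 1 to compound 2 (0.05 log units; within the scatter), where the same acyl group was added on an oxygen on a saturated carbon without moving the number beyond the scatter. Removing a group of this kind from the other oxygen is therefore expected to leave this assay essentially unchanged, with no step beyond the scatter in either direction.

Compound 3 is accordingly estimated at 2600000 nM, with a range from 1200000 nM to 5500000 nM. The expected step of a 1.1-fold lower number from compound 2 to compound 3 (0.03 log units; within the scatter) is estimated to fall within the scatter.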

Compound 3, concentration for 50% growth inhibition: 2100000 nM
Beside the measured number, compound 3's estimate is 1.2-fold (0.09 log units) above it; the measured number falls inside the stated range.
By their numbers in this assay, from the lowest: compounds 3, 1 and 2 (each within the scatter of the next).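

In this assay, removing the (1-amino-2-methylpropyl)carbonyl group from the oxygen of the hydroxymethyl arm gives a 1.3-fold lower number from compound 2 to compound 3 (0.12 log units; within the scatter), so this position now has a reading of its own, and the step stays inside the scatter. Alongside a 1.1-fold higher number from compound 1 to compound 2 (0.05 log units; within the scatter), this means that the acyl group on either oxygen of compound 2 has been tested by a single change, and neither change separates the compounds in this assay. No measured evidence bears on why the three numbers stay so close.

Going by these compounds, compounds 1, 2 and 3 all carry at least one (1-amino-2-methylpropyl)carbonyl group, so the reading of the core with a free hydroxy at both places remains open. Also open, on these data alone, is whether a different acyl group on either oxygen, such as benzoyl or a longer chain like hexanoyl, would produce a step beyond the scatter in this assay.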